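The source may hold more compounds than are shown below. What is called first, only, known or untested is meant among the compounds shown, and "the series" means these compounds.

Compound 1 `Cc1ccc(CN2C(=O)/C(=N\NC(=S)Nc3ccc(Cl)cc3)c3cc(Cl)ccc32)cc1`: 5800 nM. Compound 2 `O=C1/C(=N\NC(=S)Nc2ccc(Cl)cc2)c2cc(Cl)ccc2N1Cc1ccc(Cl)cc1`: 58000 nM. Compound 3 `O=C1/C(=N\NC(=S)Nc2ccc(Cl)cc2)c2cc(Br)ccc2N1Cc1ccc(F)cc1`: 48000 nM.

In a functional assay on MOLT-4 cells (Homo sapiens), with a stated time of 72 h (on this read-out lower numbers stand for stronger inhibition and higher numbers for weaker inhibition), compound 2 gives 58000 nM and compound 1 gives 5800 nM, so a 10-fold lower number from compound 2 to compound 1 (1.00 log units; beyond the scatter) with methyl in place of chloro on an aromatic carbon. Compound 3 gives 48000 nM; how its core differs from that of compound 2 is not broken down here. Compound 4 `Cc1ccc(NC(=S)N/N=C2\C(=O)N(Cc3ccc(F)cc3)c3ccc(Br)cc32)cc1` is not yet measured. It differs from compound 3 by methyl in place of chloro on an aromatic carbon. This is the same kind of change as from compound 2 to compound 1, but the surroundings differ: there the wider reading was 4-chlorobenzyl to 4-methylbenzyl, here it is (4-chlorophenyl)amino to (4-methylphenyl)amino. Because a 10-fold lower number from compound 2 to compound 1 (1.00 log units; beyond the scatter), a step of a 3.2-fold lower number from compound 3 to compound 4 (0.51 log units; beyond the scatter) is expected, held smaller since the place differs. Compound 4 is thus estimated at 15000 nM, between 5000 nM and 45000 nM.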

Compound 4, half-maximal inhibitory concentration: 57000 nM
Estimate against measurement, compound 4: 3.8-fold (0.58 log units) below; the whole stated range lies below it.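

In this assay, putting methyl in place of chloro on the (4-chlorophenyl)amino group gives a 1.2-fold higher number from compound 3 to compound 4 (0.07 log units; within the scatter), so this pair cannot be told apart. The same swap made on the benzyl group of the other pair gave a clearly different result: the same change on two cores in this assay, a 10-fold lower number (1.00 log units; beyond the scatter) from compound 2 to compound 1 and a 1.2-fold higher number (0.07 log units; within the scatter) from compound 3 to compound 4, 12-fold (1.07 log units) apart, beyond the scatter of two such steps The size of this swap therefore cannot simply be carried from one place or core to another in this series, but two pairs do not show why the results differ, since the pairs differ in more than the swap itself.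

Still open, on these data alone, is whether the same swap on the (4-chlorophenyl)amino group of compound 2 would also leave the number unmoved. As far as these compounds go, it is also open how an amine or a methoxy group would read in that place.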